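Urea series: removing one trifluoromethyl from compound 3

This account rests on a few compounds, and the source may have more. Where it says the series, first, only, none or still open, it means among the compounds named here.

Measured so far in a functional assay on HT-29 cells (Homo sapiens) for inhibition, read by sulforhodamine B assay, with a stated time of 48 h, tested at 0.1 uM; a lower number here means a stronger effect, a higher number a weaker effect of the compound at the concentration tested:
compound 1 `O=C(Nc1cccc(-n2cc(-c3ccncc3)c(-c3cc(O)cc(Cl)c3)n2)c1)Nc1ccc(Cl)c(C(F)(F)F)c1` — compound 1 gives 93%
compound 2 `COc1cc(Cl)cc(-c2nn(-c3cccc(NC(=O)Nc4ccc(Cl)c(C(F)(F)F)c4)c3)cc2-c2ccncc2)c1` — compound 2 gives 94%
compound 3 `COc1cc(Cl)cc(-c2nn(-c3cccc(NC(=O)Nc4cc(C(F)(F)F)cc(C(F)(F)F)c4)c3)cc2-c2ccncc2)c1` — compound 3 gives 101%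

All three numbers sit close to one another. Compound 3 stands at 101%; compound 2 and compound 1 lie within the scatter of it, so none of the three can be set apart from the others on this read-out. Going by the values given here, the one step with a single change, a number 1 percentage points higher from compound 1 to compound 2 (within the scatter), shows how little a change on the oxygen side of the molecule moved the number.

Compound 4 `COc1cc(Cl)cc(-c2nn(-c3cccc(NC(=O)Nc4cccc(C(F)(F)F)c4)c3)cc2-c2ccncc2)c1` is next. It differs from compound 3 as follows: hydrogen in place of trifluoromethyl on an aromatic carbon. Among the compounds with values here, no measured step touches the urea aryl group in this way, so the only guide is that all three measured compounds, with two different substitution patterns on that ring, give values in the same band. The expectation is therefore a step of a number 4 percentage points lower from compound 3 to compound 4 (within the scatter), that is, none beyond the scatter. For compound 4 the estimate in this assay is 97%, expected to fall between 85% and 108%.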

Compound 4, a percentage reported as activity, at one concentration (the size of the read-out at that concentration, not a potency): 95%
Compound 4: the middle estimate sits 2 percentage points above what was measured, within the range that was stated.
By their numbers in this assay, from the lowest: compounds 1, 2, 4 and 3 (each within the scatter of the next).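

In this assay, going by these compounds alone, hydrogen in place of trifluoromethyl on the urea aryl ring gives a number 6 percentage points lower from compound 3 to compound 4 (within the scatter), the first directly readable step at this ring, and it does not separate the two compounds. Hydrogen in place of chloro on the same ring gives a number 1 percentage points higher from compound 2 to compound 4 (within the scatter), so neither of these two single changes on this ring produces a step beyond the scatter, and the ring without a second substituent gives a value in the same band as the rings carrying one. No measurement is at hand that bears on the reason for these results.

The compounds shown leave open whether any group on this ring can move the number beyond the scatter in this assay, for example an amine, a carboxylic acid or a longer chain in place of the remaining trifluoromethyl. Since the read-out comes from a single concentration, they also leave open whether compound 3 and compound 4 would differ at any other concentration.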